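The compounds below may be only part of what the source reports. "The series", "measured", "known", "first", "only" and "open" are said of these compounds alone.

Among the compounds with values here, compound 2 `COc1ccc2nc(C)cc(OCC(=O)Nc3ccc(C)cc3)c2c1` gives 17000 nM in a physicochemical assay for solubility, measured as kinetic solubility, at pH 5.8 (a higher number here means a more soluble compound, a lower number a less soluble compound), the highest of the three numbers measured so far; compound 1 `COc1ccc2nc(C)cc(OCC(=O)Nc3ccc4c(c3)CCC4)c2c1` gives 2800 nM, and compound 3 `COc1ccc2nc(C)cc(OCC(=O)Nc3ccc4c(c3)CCCC4)c2c1` gives 6600 nM. Compound 4 `CCCc1ccc(NC(=O)COc2cc(C)nc3ccc(OC)cc23)cc1` differs from compound 2 by ethyl in place of hydrogen on a saturated chain carbon bound to an aromatic carbon. Within the data shown here, the one measured step that bears on this is a 6.1-fold higher number from compound 1 to compound 2 (0.78 log units; beyond the scatter), in which 4-methylphenyl took the place of 2,3-dihydro-1H-inden-5-yl and the number rose. Compound 3 sits between the other two. Since adding carbon to the 4-methylphenyl group runs against that step, a lower number is expected, though of a smaller size. The expected step is a 2.8-fold lower number from compound 2 to compound 4 (0.45 log units; beyond the scatter). Compound 4 is estimated at 6000 nM, with a range from 2000 nM to 16000 nM.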

Compound 4, solubility: 3900 nM
Estimate against measurement, compound 4: 1.5-fold (0.19 log units) above, within the range that was stated.
By their numbers in this assay, from the lowest: compounds 1, 4 and 3 (each within the scatter of the next, the first and the last beyond it); then compound 2.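

In this assay the change from methyl to propyl on the 4-methylphenyl group gives a clear step (a 4.4-fold lower number from compound 2 to compound 4 (0.64 log units; beyond the scatter)), so the chain alone, with no ring added, is enough to move the number beyond the scatter. The open 4-propylphenyl group and the 2,3-dihydro-1H-inden-5-yl group of compound 1 cannot be told apart here (a 1.4-fold higher number from compound 1 to compound 4 (0.14 log units; within the scatter)). No evidence at hand accounts for either step. Still open, from the compounds shown here alone, is how the number would respond to the 4-ethylphenyl group, which lies on the way from methyl to propyl, or to a longer chain such as butyl. An amine or a carboxylic acid at the end of the chain also remains untested among these compounds.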